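Replacing 1H-indol-4-yl on the shared core: a solubility estimate

This account rests on a few compounds, and the source may have more. Where it says the series, first, only, none or still open, it means among the compounds named here.

Measured in a physicochemical assay for solubility; on this read-out lower numbers stand for lower solubility and higher numbers for higher solubility:
Compound 1 `CNC(=O)c1cc(C(=O)NC2CC2)cn(Cc2ccc(OC)cc2)c1=O`: >= 143 ug/mL
Compound 2 `CNC(=O)c1cc(C(=O)NC2CC2)cn(Cc2cccc3[nH]ccc23)c1=O`: 78 ug/mL

The entry for compound 1 is a limit and not a number. Within the data shown here, that leaves compound 2, at 78 ug/mL, with the only true number so far. Compound 3 `CNC(=O)c1cc(C(=O)NC2CC2)cn(Cc2cccc([C@@H](C)O)c2)c1=O` differs from it by 3-(1-hydroxyethyl)phenyl in place of 1H-indol-4-yl on a saturated chain carbon bound to an aromatic nitrogen. Among the measured compounds shown here, the one measured step at this place, an at least 1.8-fold lower number from compound 1 to compound 2 (0.26 log units; that floor lies within the scatter), is the only guide. That step brought 1H-indol-4-yl in for 4-methoxyphenyl, and here 1H-indol-4-yl leaves again, so a small rise in this assay is expected. The estimated change is a 1.8-fold higher number from compound 2 to compound 3 (0.25 log units; within the scatter). For compound 3 the expected value is 140 ug/mL, within an estimated range of 65 ug/mL to 300 ug/mL.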

Compound 3, solubility: >= 131 ug/mL
Compound 3 ended at the assay's limit; the forecaster's own chance of this, stated with the estimate: 35%; the middle value lies beyond the limit too.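

In this assay, 3-(1-hydroxyethyl)phenyl on a saturated chain carbon bound to an aromatic nitrogen gives an at least 1.6-fold higher number from compound 2 to compound 3 (0.22 log units; that floor lies within the scatter). The entry for compound 3 is a limit and not a number: the limit of >= 131 ug/mL in this assay, at which 1 of the 3 values shown sits.

Among these compounds, with compound 1 also at a limit, the step from compound 1 to compound 3 cannot be read, and 1H-indol-4-yl remains the only group at this place with a true number. As far as these compounds go, how far compound 3 lies past its limit stays open. Also open, from the compounds shown here alone, is whether a group carrying an amine or a carboxylic acid at this place would give a true number in this assay.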